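The compounds below may be only part of what the source reports. "The series", "measured", "known", "first", "only" and "open" are said of these compounds alone.

Measured so far:
- Compound 1, `Cc1c(C(N)=O)sc2nc(NN)n(Cc3ccccc3)c(=O)c12`: 44.8%
- Compound 2, `Cc1c(C(N)=O)sc2nc(N/N=C/c3ccc(Br)cc3)n(Cc3ccccc3)c(=O)c12`: 34.4%
- Compound 3, `Cc1c(C(N)=O)sc2nc(-n3nc(-c4ccc(Cl)cc4)cc3N)n(Cc3ccccc3)c(=O)c12`: 40.3%

In a functional assay on the whole organism (strain albino) for inhibition, with Rattus norvegicus as the target, with a stated time of 1 h, at a dose of 10 mg/kg by the oral route (on this read-out higher numbers stand for more inhibition at the one dose given (going by the name of the read-out) and lower numbers for less inhibition), compound 2 gives 34.4%, the lowest of the three numbers. Compound 3 gives 40.3%, which lies within the scatter of compound 2. Within the data shown here, compound 1 gives 44.8%, and the single step with one change, a number 10.4 percentage points lower from compound 1 to compound 2 (beyond the scatter), is the only one beyond the scatter.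

The unmeasured compound 4, `CC1=NN(c2nc3sc(C(N)=O)c(C)c3c(=O)n2Cc2ccccc2)C(=O)C1`, differs from compound 2 in one place: a group of 7 heavy atoms (4 carbon, 2 nitrogen, 1 oxygen; one five-membered non-aromatic ring with 2 hetero atoms) in place of a group of 10 heavy atoms (7 carbon, 2 nitrogen, 1 bromine; one six-membered aromatic ring of carbon only), on an aromatic carbon. Among the measured compounds shown here, no measured step covers this kind of exchange. For the measured compounds named here, the one step that does bear on it is the one from compound 1 to compound 2, where a bromophenyl-bearing group took the place of a single nitrogen atom and inhibition fell modestly. Compound 4 removes that bromophenyl-bearing group again, but brings in a five-membered non-aromatic ring instead of returning to the bare nitrogen, so the step is not a reversal. The expectation is therefore a step of a number 5.6 percentage points higher from compound 2 to compound 4 (within the scatter), small and most likely within the scatter, with a slight lean upward. Compound 4 is estimated at 40%, with a range from 27% to 53%.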

Compound 4, a percentage reported as inhibition, in the whole organism at one dose (the size of the read-out at that dose, not a potency): 38.9%
Compound 4: middle estimate off by 1.1 percentage points, on the high side, within the range that was stated.
By their numbers in this assay, from the lowest: compounds 2, 4, 3 and 1 (each within the scatter of the next, the first and the last beyond it).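

In this assay, compound 4 carries a five-membered non-aromatic ring with 2 hetero atoms on the aromatic carbon between two ring nitrogen atoms, and both steps to it are small: a number 4.5 percentage points higher from compound 2 to compound 4 (within the scatter) and a number 5.9 percentage points lower from compound 1 to compound 4 (within the scatter). Compound 1 and compound 2 can be told apart at this position, but compound 4 cannot be told apart from either, so this ring, with its 0 hydrogen-bond donors and no six-membered aromatic ring of carbon only, keeps the read-out in the same range as both earlier groups. No independent measurement is available to explain this result.

The compounds shown leave open how a simple amine, a morpholine ring or a carboxylic acid on this same carbon would compare, and whether a larger difference can be obtained here at all. Each number also comes from a single dose, so these compounds do not show how the inhibition would change at other doses, or whether the differences seen here would hold at them.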